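A shift from cyclohexanol to a fused oxacycle on the amide

The source may report more compounds than this note shows. Statements on the series, on what has been measured and on what is new or still open speak of the compounds shown alone.

Measured compounds:
Compound 1 `CNC(=O)c1cc(C(=O)N[C@H]2CC[C@H](O)CC2)cc2c1OC[C@@]2(C)c1ccccc1` — 3.3
Compound 2 `CNC(=O)c1cc(C(=O)Nc2cnn(C)c2)cc2c1OC[C@H]2c1ccccc1` — 3.5
Compound 3 `CNC(=O)c1cc(C(=O)NC2CC2)cc2c1OC[C@H]2c1cccc(OC)c1` — 3.8

Of the compounds shown here, three sharing the same core have been measured in a physicochemical assay for lipophilicity, at pH 7.4; a higher number here means a more lipophilic compound, a lower number a more polar compound. Compound 1 gives 3.3, the lowest of the three numbers. Compound 2 gives 3.5, which sits within the usual scatter of compound 1, so the two cannot be told apart on this evidence. Compound 3 gives 3.8, a number that lies beyond the scatter above compound 1. No two of these compounds differ in only one place, so no single step between measured compounds can be read off.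

Compound 4 `CNC(=O)c1cc(C(=O)N[C@H]2[C@@H]3COC[C@@H]32)cc2c1OC[C@@]2(C)c1ccccc1` has not yet been measured in this assay. It differs from compound 1 on the amide-type nitrogen whose other neighbour is the carbonyl carbon: a group of 6 heavy atoms (5 carbon, 1 oxygen; one three-membered non-aromatic ring of carbon only, one five-membered non-aromatic ring with 1 hetero atom) in place of a group of 7 heavy atoms (6 carbon, 1 oxygen; one six-membered non-aromatic ring of carbon only), on an amide-type nitrogen. The group that leaves carries one hydrogen-bond donor and one acceptor; the group that enters carries no donor and one acceptor, and is one heavy atom smaller.

Going by the values given here, nothing among the measured compounds tests this exact exchange. The step from compound 1 to compound 4 is therefore expected to be small and upward, a number 0.30 log units higher from compound 1 to compound 4 (within the scatter), close to the edge of the scatter. Compound 4 is accordingly estimated at 3.6, with a range from 3.1 to 4.1.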

Compound 4, distribution coefficient: 3.7
The estimate for compound 4 lay 0.10 log units below the measured number; low and high end bracket the measured number.
By their numbers in this assay, from the lowest: compounds 1, 2, 4 and 3 (each within the scatter of the next, the first and the last beyond it).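

In this assay, going by these compounds alone, exchanging the 4-hydroxycyclohexyl group on the amide-type nitrogen for a group with one three-membered and one five-membered non-aromatic ring gives a number 0.40 log units higher from compound 1 to compound 4 (beyond the scatter), the only step in this set that can be read at this position with the rest of the structure held constant. The group that enters is one heavy atom smaller and carries no hydrogen-bond donor, whereas the group that leaves carries one, so in this pair the smaller group goes with the higher number. No measured information on the reason for this step is at hand, and the changes in donor count, ring type and size cannot be told apart here.

The compounds shown leave open which of these changes goes with the step: a plain cyclohexyl group or a 4-methoxycyclohexyl group on the same nitrogen would separate the loss of the hydroxyl hydrogen from the change of ring. Also open, from the compounds shown here alone, is how an amine in place of the oxygen of the entering group would read in this assay, and whether this exchange gives a step of similar size on another core.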